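This account rests on a few compounds, and the source may have more. Where it says the series, first, only, none or still open, it means among the compounds named here.

Series in a functional assay on K562 cells (Homo sapiens) for antiproliferative activity, read by MTT assay, with a stated time of 48 h; on this read-out higher numbers stand for weaker inhibition and lower numbers for stronger inhibition:
Compound 1 `Cn1cc(C2=C(c3nn(CCCn4ccnc4)c4ncccc34)C(=O)N(c3ccccc3)C2=O)c2ccccc21`: 5510 nM
Compound 2 `Cn1cc(C2=C(c3nn(CCCN4CCCCC4)c4ncccc34)C(=O)N(c3ccccn3)C2=O)c2ccccc21`: > 100000 nM (a limit of the assay)
Compound 3 `Cn1cc(C2=C(c3nn(CCCn4ccnc4)c4ncccc34)C(=O)NC2=O)c2ccccc21`: 13800 nM

Compound 3 has the higher of the two numeric values, at 13800 nM. The value of compound 1 is 5510 nM, and the measured step is a 2.5-fold higher number from compound 1 to compound 3 (0.40 log units; beyond the scatter). That step places hydrogen in place of phenyl on an amide-type nitrogen in a ring. Compound 2 sits at the limit of > 100000 nM in this assay, at which 1 of the 3 values shown sits. Going by the values given here, it differs from compound 1 in more than one place, so it supplies no single-change step.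

The next change leads to compound 4 `Cn1cc(C2=C(c3n[nH]c4ncccc34)C(=O)NC2=O)c2ccccc21`: hydrogen in place of 3-(1H-imidazol-1-yl)propyl on an aromatic nitrogen. In words, this is hydrogen in place of 3-(1H-imidazol-1-yl)propyl on an aromatic nitrogen.

Among the compounds with values here, no measured step touches this aromatic nitrogen. Within the data shown here, the only guide is the modest step at the other nitrogen, a 2.5-fold higher number from compound 1 to compound 3 (0.40 log units; beyond the scatter), which also replaced a group with hydrogen and raised the number. It bears on the new change only indirectly, so the central expectation in this assay is a small upward move that may not clear the scatter. The expected step is a 1.3-fold higher number from compound 3 to compound 4 (0.12 log units; within the scatter). For compound 4 the estimate is 18000 nM, with an expected range from 5000 nM to 70000 nM.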

Compound 4, half-maximal inhibitory concentration: > 100000 nM
Compound 4 ended at the assay's limit; the forecaster's own chance of this, stated with the estimate: 20%; middle value at least 5.5-fold (0.74 log units) from the limit.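

In this assay, the aromatic nitrogen proves a sensitive position: hydrogen in place of 3-(1H-imidazol-1-yl)propyl gives an at least 7.2-fold higher number from compound 3 to compound 4 (0.86 log units; beyond the scatter), whereas the earlier change at the amide-type nitrogen gave a 2.5-fold higher number from compound 1 to compound 3 (0.40 log units; beyond the scatter). Compound 4 reads > 100000 nM, which is a limit of the assay and not a number, so the step has a lower bound only and its full size cannot be read. A chain on this nitrogen is not enough on its own to keep a measurable value, as compound 2 also carries one and ends at a limit, though it differs from compound 1 in more than one place: the limit of > 100000 nM in this assay, at which 2 of the 4 values shown sit.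

The compounds shown do not separate the part played by the imidazole ring from that of the propyl chain, so a plain methyl, a propyl chain ending in a hydroxyl or a primary amine, or a longer chain ending in the same imidazole would each bear on this. As far as these compounds go, it also stays open whether hydrogen on this nitrogen has the same outcome when phenyl stays on the amide-type nitrogen.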